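A single methyl on a fast-cleared compound

The compounds below may be only part of what the source reports. "The series", "measured", "known", "first", "only" and "open" are said of these compounds alone.

In an ADME assay on the whole organism (Mus musculus, strain C57BL/6J) for pharmacokinetics, with a stated time of 24 h, at a dose of 2 mg/kg by the intravenous route (a higher number here means faster removal of the compound, a lower number slower removal), compound 1 `CCCCOc1nc(OCC(C)(C)O)c(-c2ccc(S(C)(=O)=O)cc2)cc1C(C)O` gives 48.2 mL/min/kg, compound 2 `CCCCOc1nc(-c2ccc(F)cc2)c(-c2ccc(S(C)(=O)=O)cc2)cc1CO` gives 32.2 mL/min/kg, and compound 3 `CCCCOc1nc(OCC2COC2)c(-c2ccc(S(C)(=O)=O)cc2)cc1CO` gives 102 mL/min/kg, the highest of the three numbers. Compound 4 `CCCCOc1nc(OCC2(C)COC2)c(-c2ccc(S(C)(=O)=O)cc2)cc1CO` differs from compound 3 by one small change, methyl in place of hydrogen on a saturated ring carbon: (oxetan-3-yl)methoxy becomes (3-methyloxetan-3-yl)methoxy. Within the data shown here, only one measured step bears on this, and only loosely. That step, a 3.2-fold higher number from compound 2 to compound 3 (0.50 log units; beyond the scatter), exchanged a whole 4-fluorophenyl group for (oxetan-3-yl)methoxy, so a lone methyl in place of hydrogen is expected to move this assay by less, with a slightly lower number at most. The expected change is a 1.2-fold lower number from compound 3 to compound 4 (0.08 log units; within the scatter), which stays within the scatter. For compound 4 the estimated clearance is 85 mL/min/kg, with an expected range of 45 mL/min/kg to 140 mL/min/kg.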

Compound 4, clearance: 89.3 mL/min/kg
Beside the measured number, compound 4's estimate is 1.1-fold (0.02 log units) below it, and the stated range covers the measured number.
By their numbers in this assay, from the lowest: compounds 2, 1, 4 and 3 (each within the scatter of the next, the first and the last beyond it).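

In this assay, methyl in place of hydrogen on this saturated ring carbon gives a 1.1-fold lower number from compound 3 to compound 4 (0.06 log units; within the scatter) and so leaves compound 3 and compound 4 indistinguishable. The gap to the 4-fluorophenyl compound also persists with the methyl in place, with a 2.8-fold higher number from compound 2 to compound 4 (0.44 log units; beyond the scatter) and still beyond the scatter. Still open, on these data alone, is whether a larger group on this ring carbon, such as an amine or a longer chain, would move the number beyond the scatter. Nothing shown here gives a measured explanation for this result.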